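The source may hold more compounds than are shown below. What is called first, only, known or untested is meant among the compounds shown, and "the series" means these compounds.

For the measured compounds named here, compound 2, `C[C@@H](NC(=O)Nc1ccc(C(C)(C)C)cc1)c1ccccc1`, stands highest of the two numbers so far: in an ADME assay on the whole organism with Oryza sativa as the target, tested at 1 uM (a lower number here means a stronger effect, a higher number a weaker effect of the compound at the concentration tested), compound 2 gives 88%. Going by the values given here, its only neighbour, compound 1, `CCCc1ccc(NC(=O)N[C@H](C)c2ccccc2)cc1`, gives 31%. Among the compounds with values here, the one measured step that bears on the new compound is a number 57 percentage points higher from compound 1 to compound 2 (beyond the scatter). Compound 3, `CCCCCc1ccc(NC(=O)N[C@H](C)c2ccccc2)cc1`, carries the change (pentyl in place of tert-butyl on an aromatic carbon). A pentyl chain is, like the propyl of compound 1, a straight chain rather than a tert-butyl. On that ground the expected step is a number 43 percentage points lower from compound 2 to compound 3 (beyond the scatter), downward and large. For compound 3 the estimated value is 45%, with a range from 15% to 80%.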

Compound 3, a percentage reported as activity, at one concentration (the size of the read-out at that concentration, not a potency): 101%
Compound 3: middle estimate off by 56 percentage points, on the low side, outside the stated range (above it).
By their numbers in this assay, from the lowest: compound 1; then compound 2; then compound 3.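

Within the straight chains, length matters at this position: pentyl in place of propyl gives a number 70 percentage points higher from compound 1 to compound 3 (beyond the scatter) in this assay. A straight chain therefore does not by itself bring a low number, and pentyl even stands above tert-butyl, with a number 13 percentage points higher from compound 2 to compound 3 (beyond the scatter) and compound 1 still lowest of the three. No measurement here explains why these groups differ.

Still open, going by these compounds, is how a shorter ethyl or a longer heptyl would read at this place, and whether a chain ending in an amine or a carboxylic acid would follow the same course.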